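Methyl to Ethyl on a Compound Held at a Limit

The source may report more compounds than this note shows. Statements on the series, on what has been measured and on what is new or still open speak of the compounds shown alone.

Measured so far:
compound 1 `CCC(=O)N[C@@H]1CCCc2c1cncc2N1C(=O)c2ccc(Cl)cc2[C@@H]1C` gives a limit (< 20.2 mL/min/kg)
compound 2 `CC(=O)N[C@@H]1CCCc2c1cncc2N1C(=O)c2ccc(Cl)cc2[C@@H]1C` gives a limit (< 20.2 mL/min/kg)

In an ADME assay on microsomes from liver (Mus musculus) for metabolic stability, read by LC-MS, using NADPH, with stated times of 10 min and 30 min (a higher number here means faster removal of the compound, a lower number slower removal), compound 1 gives only a limit (< 20.2 mL/min/kg) and no number. Compound 2 also gives only a limit (< 20.2 mL/min/kg) and no number. Both therefore rest on one reading (the limit of < 20.2 mL/min/kg in this assay, at which 2 of the 2 values shown sit) and neither can be placed more exactly.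

Compound 3 `CCC(=O)N[C@@H]1CCCc2c1cncc2N1C(=O)c2ccc(Cl)cc2[C@@H]1CC` keeps the core of compound 1 and differs in one place (methyl in place of hydrogen on a saturated chain carbon bound to a saturated ring carbon): methyl in place of hydrogen on a saturated chain carbon bound to a saturated ring carbon, so that methyl becomes ethyl. Going by the values given here, only one measured step exists (a step that the two limits leave unreadable from compound 1 to compound 2), and it lies elsewhere, on a saturated chain carbon bound to a carbonyl carbon. It offers no size to carry over. The expectation therefore rests on the limit of compound 1 (< 20.2 mL/min/kg) and on the smallness of the change. No shift beyond the scatter is expected in this assay, and no direction can be argued with confidence. The expected step runs (a step that the limit leaves unreadable from compound 1 to compound 3) and is an estimate only. Compound 3 is estimated at 16 mL/min/kg (8 mL/min/kg to 32 mL/min/kg).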

Compound 3, clearance: < 20.2 mL/min/kg
Compound 3 was reported as a limit; the forecaster's own chance of this, stated with the estimate: 65%; the middle value is on the limit's open side.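

In this assay, going by these compounds alone, compound 3 gives only a limit, as compound 1 does, so no step between compound 1 and compound 3 can be read. All the values shown rest on one reading: the limit of < 20.2 mL/min/kg in this assay, at which 3 of the 3 values shown sit. The compounds shown leave open how compound 1, compound 2 and compound 3 compare in clearance, and whether methyl to ethyl changes it at all.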